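The source may report more compounds than this note shows. Statements on the series, on what has been measured and on what is new or still open speak of the compounds shown alone.

Compounds measured so far in a functional assay on A549 cells (Homo sapiens) for cytotoxicity, read by MTT assay, with a stated time of 72 h; a lower number here means a stronger inhibitor, a higher number a weaker inhibitor:
compound 1 `Cc1cc(=O)n(-c2ccccc2OC(F)(F)F)nc1C(=O)Nc1ccc(Oc2ncnc3ccsc23)cc1` gives 10100 nM
compound 2 `Cc1cc(=O)n(-c2ccc(Br)cc2F)nc1C(=O)Nc1ccc(Oc2ncnc3sccc23)cc1` gives 12800 nM
compound 3 `Cc1cc(=O)n(-c2ccccc2OC(F)(F)F)nc1C(=O)Nc1ccc(Oc2ncnc3sccc23)cc1` gives 15500 nM

All three numbers for compound 1, compound 2 and compound 3 sit close together in this assay. Compound 3 has the highest of the three numbers, but its nearest neighbour is compound 2 and the gap between them, a 1.2-fold higher number from compound 2 to compound 3 (0.08 log units; within the scatter), lies within the scatter, as does a 1.5-fold higher number from compound 1 to compound 3 (0.19 log units; within the scatter) to compound 1. Nothing in these values sets compound 3 apart from the other two.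

Compound 4 `Cc1cc(=O)n(-c2ccc(F)c(F)c2)nc1C(=O)Nc1ccc(Oc2ncnc3sccc23)cc1` differs from compound 3 in one place: 3,4-difluorophenyl in place of 2-(trifluoromethoxy)phenyl on an aromatic nitrogen. Going by the values given here, the step that bears on this is the one from compound 2 to compound 3, which also exchanged the aryl group on the aromatic nitrogen and produced only a 1.2-fold higher number from compound 2 to compound 3 (0.08 log units; within the scatter). On this evidence an exchange of that aryl group has not moved the number beyond the scatter, so compound 4 is expected to stay close to compound 3 in this assay, with no step beyond the scatter, which is what the estimated step of a 1.2-fold lower number from compound 3 to compound 4 (0.08 log units; within the scatter) means. Compound 4 is therefore estimated at 13000 nM, with a range from 6000 nM to 28000 nM.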

Compound 4, half-maximal inhibitory concentration: 13500 nM
Compound 4: middle estimate off by 1.0-fold (0.02 log units), on the low side; measured number inside the range.
By their numbers in this assay, from the lowest: compounds 1, 2, 4 and 3 (each within the scatter of the next).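

In this assay, the exchange of 2-(trifluoromethoxy)phenyl for 3,4-difluorophenyl on the aromatic nitrogen gives a 1.1-fold lower number from compound 3 to compound 4 (0.06 log units; within the scatter), even though the entering group has fewer heavy atoms and, unlike the group it replaces, no hydrogen-bond acceptor. Going by these compounds alone, the exchange of 4-bromo-2-fluorophenyl for the same group gives a 1.1-fold higher number from compound 2 to compound 4 (0.02 log units; within the scatter), so with the core of compound 2, compound 3 and compound 4 held constant, three differently substituted phenyl groups at this position now fall within the scatter of one another, where the earlier compounds offered only a single such exchange. Nothing measured here accounts for this flat result.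

From the compounds shown here alone, all three groups at this position are phenyl rings bearing fluorine, bromine or trifluoromethoxy, so it remains open whether the number would stay in this range with an amine or a carboxylic acid on the phenyl ring, or with a longer alkyl chain in place of the ring. Going by these compounds, it is also open whether 3,4-difluorophenyl would behave the same way on the core of compound 1, which appears here only with 2-(trifluoromethoxy)phenyl.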